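This account rests on a few compounds, and the source may have more. Where it says the series, first, only, none or still open, it means among the compounds named here.

Measured compounds in a physicochemical assay for solubility, using the shake flask method, measured as kinetic solubility, with a stated time of 20 h, at pH 2; on this read-out higher numbers stand for higher solubility and lower numbers for lower solubility:
- compound 1, `FC(F)(F)c1cccc(-c2nc3cnc(Nc4ccccn4)cc3[nH]2)c1`: 21000 nM
- compound 2, `FC(F)(F)c1cccc(-c2nc3cnc(Nc4ccncn4)cc3[nH]2)c1`: 200000 nM

Compound 2 gives the higher of the two numbers in this assay, and compound 1 sits a clear gap below it. For the measured compounds named here, the only step seen so far, a 9.5-fold higher number from compound 1 to compound 2 (0.98 log units; beyond the scatter), replaced pyridin-2-yl by pyrimidin-4-yl on a nitrogen on an aromatic ring.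

Compound 3, `N#Cc1ccc(Nc2cc3[nH]c(-c4cccc(C(F)(F)F)c4)nc3cn2)nc1`, is not yet measured. It differs from compound 2 as follows: 5-cyanopyridin-2-yl in place of pyrimidin-4-yl on a nitrogen on an aromatic ring. Going by the values given here, this change bears a partial relation to the one step seen: it reintroduces a pyridin-2-yl ring, the group whose presence in compound 1 went with the lower number, but now carrying a nitrile, for which no comparison exists. A return toward compound 1 is therefore expected, though softened by the unknown contribution of the nitrile; the expected step is a 4.4-fold lower number from compound 2 to compound 3 (0.65 log units; beyond the scatter). Compound 3 is estimated at 45000 nM, in the range 12000 nM to 170000 nM.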

Compound 3, solubility: < 5000 nM
Compound 3: only a limit was reported; the forecaster's own chance of this, stated with the estimate: 5%; middle value at least 9.0-fold (0.95 log units) from the limit.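

In this assay, the value for compound 3 is a limit of the assay and not a number: the limit of < 5000 nM in this assay, at which 1 of the 3 values shown sits. Changing the ring on this nitrogen can move the number a long way, since 5-cyanopyridin-2-yl in place of pyrimidin-4-yl gives an at least 40-fold lower number from compound 2 to compound 3 (1.60 log units; beyond the scatter). Putting cyano in place of hydrogen on the pyridin-2-yl ring gives an at least 4.2-fold lower number from compound 1 to compound 3 (0.62 log units; beyond the scatter), so the nitrile-bearing ring does not simply return to the level of the unsubstituted pyridin-2-yl ring, but lies lower.

Going by these compounds, both steps rest on a limit, so their true size stays open. Also open, on these data alone, is whether a nitrile on the pyrimidin-4-yl ring would lower the number in the same way, and how an amine or a carboxylic acid would compare with the nitrile on the pyridin-2-yl ring.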